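This account rests on a few compounds, and the source may have more. Where it says the series, first, only, none or still open, it means among the compounds named here.

Within the data shown here, in an ADME assay on J774.A1 cells (Mus musculus) for inhibition, read by MTT assay, with a stated time of 72 h (on this read-out higher numbers stand for an effect only at larger amounts of compound and lower numbers for an effect already at smaller amounts), compound 1 (`CC(C)Nc1nc(Nc2ccccc2)c2ccccc2n1`) gives 12000 nM and compound 2 (`CC(C)Nc1nc(NCC2CCCO2)c2ccccc2n1`) gives 46000 nM as the higher of the two numbers so far. Among the measured compounds shown here, compound 3 (`CC(C)Nc1nc(NC(C)C)c2ccccc2n1`) changes the same nitrogen substituent as the only measured step: isopropyl in place of (oxolan-2-yl)methyl on a nitrogen on an aromatic ring.

For the measured compounds named here, the one step bearing on this is the exchange of phenyl for (oxolan-2-yl)methyl (a 3.8-fold higher number from compound 1 to compound 2 (0.58 log units; beyond the scatter)), which is modest but beyond the scatter. It involves neither an isopropyl group at this place nor any other open-chain group, so it guides the size of the next step better than its direction. Going by the values given here, with only two measured compounds, no trend can be claimed. Since compound 2 stands at the top of the measured range with 46000 nM, a modest move to a lower number in this assay is the more likely outcome, of about the size of the measured step or smaller.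

The expected change is a 1.8-fold lower number from compound 2 to compound 3 (0.25 log units; within the scatter) and remains uncertain. For compound 3 the estimated value is 26000 nM, with an expected range from 11000 nM to 60000 nM.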

Compound 3, half-maximal effective concentration: > 30000 nM
Compound 3 was reported as a limit; the forecaster's own chance of this, stated with the estimate: 15%; middle value at least 1.1-fold (0.06 log units) away from the limit.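

In this assay compound 3, with isopropyl on the nitrogen on an aromatic ring, is reported only as a limit, > 30000 nM, so this result is a bound and not a number. The step between the two non-aromatic substituents cannot be read, because the value of compound 3 is a limit: the limit of > 30000 nM in this assay, at which 1 of the 3 values shown sits.

The step that can be read is an at least 2.5-fold higher number from compound 1 to compound 3 (0.39 log units; beyond the scatter), and together with a 3.8-fold higher number from compound 1 to compound 2 (0.58 log units; beyond the scatter) it shows that both the open-chain isopropyl and the ring-bearing (oxolan-2-yl)methyl give a higher number than phenyl at this nitrogen, with neither of the three compounds going against this.

As far as these compounds go, whether isopropyl and (oxolan-2-yl)methyl differ from each other at this place stays open, and so does the question of whether the lower number of compound 1 belongs to phenyl alone or extends to other aromatic groups. A benzyl group, a chlorophenyl group or a longer chain such as n-butyl on this nitrogen would show how far the difference from phenyl reaches.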